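Replacing the Sulfamoylphenyl Group of Compound 3

The source may hold more compounds than are shown below. What is called first, only, known or untested is meant among the compounds shown, and "the series" means these compounds.

Among the compounds with values here, compound 3 `COc1cc2nc(SCC(=O)Nc3ccc(S(N)(=O)=O)cc3)nc(Nc3c(Cl)cc(/C=C/C#N)cc3Cl)c2cc1OC` gives 116000 nM in an ADME assay on MT4 cells (Homo sapiens) for cytotoxicity, read by MTT assay, with a stated time of 5 days (on this read-out higher numbers stand for lower toxicity in this test and lower numbers for higher toxicity in this test), and holds the only true number among the three compounds measured so far. Compound 1 `COc1cc2nc(SCC(=O)Nc3ccc([N+](=O)[O-])cc3)nc(Nc3c(C)cc(/C=C/C#N)cc3C)c2cc1OC` gives > 219000 nM as a limit and not a number. Compound 2 `COc1ccc(NC(=O)CSc2nc(Nc3c(C)cc(/C=C/C#N)cc3C)c3cc(OC)c(OC)cc3n2)cc1` likewise gives > 225000 nM as a limit and not a number.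

The next compound, compound 4 `COc1cc2nc(SCC(=O)Nc3cc([N+](=O)[O-])ccc3F)nc(Nc3c(Cl)cc(/C=C/C#N)cc3Cl)c2cc1OC`, carries 2-fluoro-5-nitrophenyl in place of 4-sulfamoylphenyl on an amide-type nitrogen, a change counted as 2-fluoro-5-nitrophenyl in place of 4-sulfamoylphenyl on an amide-type nitrogen in full. Within the data shown here, no measured step replaces 4-sulfamoylphenyl. Among the measured compounds shown here, the one measured step touching a nitro group, a step that the two limits leave unreadable from compound 1 to compound 2, puts methoxy in place of nitro on an aromatic carbon, and it offers no size to carry over.

The expected result is therefore a 1.5-fold lower number from compound 3 to compound 4 (0.16 log units; within the scatter) and no shift beyond the usual scatter is foreseen in either direction. For compound 4 an expected value of 80000 nM with a range from 20000 nM to 230000 nM is estimated in this assay for now.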

Compound 4, half-maximal cytotoxic concentration: > 199000 nM
Compound 4: a limit, no number; the forecaster's own chance of this, stated with the estimate: 35%; at least 2.4-fold (0.39 log units) between middle value and limit.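

Within the data shown here, replacing 4-sulfamoylphenyl with 2-fluoro-5-nitrophenyl on the amide-type nitrogen gives the first readable step at this position in this assay, an at least 1.7-fold higher number from compound 3 to compound 4 (0.23 log units; that floor lies within the scatter). This fixes only a floor, and since that floor lies within the usual scatter, the step does not establish a real change on its own. Compound 4 gives a limit and not a number, so the upper end of the step stays unknown: the limit of > 199000 nM in this assay, at which 1 of the 4 values shown sits.

The compounds shown leave open whether the true value of compound 4 lies beyond the scatter from compound 3, and whether the loss of the sulfamoyl group, the fluorine or the nitro group carries the step, as these changes come together here. They also leave open how a phenyl bearing a carboxylic acid or an amine would read on the same amide-type nitrogen.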